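The compounds below may be only part of what the source reports. "The series", "measured", "known", "first", "only" and "open" are said of these compounds alone.

Compound 1 `Cc1cc(/C=C/C#N)cc(C)c1Oc1nc(Nc2ccc(N3CCCC(NS(N)(=O)=O)C3)cc2)nc2ccsc12`: in an ADME assay on MT4 cells (Homo sapiens) for cytotoxicity, read by MTT assay, with a stated time of 5 days (a lower number here means that less compound is tolerated, a higher number that more compound is tolerated), compound 1 gives > 217000 nM, which is a limit of the assay and not a number.
Compound 2 `Cc1cc(/C=C/C#N)cc(C)c1Oc1nc(Nc2ccc(N3CCN(S(N)(=O)=O)CC3)cc2)nc2sccc12`: in this assay compound 2 gives > 222000 nM, again a limit.
Compound 3 `Cc1cc(/C=C/C#N)cc(C)c1Oc1nc(Nc2ccc(N3CCN(S(C)(=O)=O)CC3)cc2)nc2sccc12`: in this assay compound 3 gives > 222000 nM, also a limit.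

Compound 1 therefore stands only at a limit, and the two other values shown are limits as well: the limit of > 217000 nM in this assay, at which 1 of the 3 values shown sits, and (the limit of > 222000 nM in this assay, at which 2 of the 3 values shown sit). Among the compounds with values here, the single measured step between neighbours, a step that the two limits leave unreadable from compound 2 to compound 3, methyl in place of amino on a sulfonyl sulfur, cannot be read from these limits.

Compound 4 `Cc1cc(/C=C/C#N)cc(C)c1Oc1nc(Nc2ccc(CN3CCN(S(N)(=O)=O)CC3)cc2)nc2ccsc12` differs from compound 1 by (4-sulfamoylpiperazin-1-yl)methyl in place of 3-(sulfamoylamino)piperidin-1-yl on an aromatic carbon. Within the data shown here, no measured step covers a change of this kind, and the one step on record gives no readable size. With all three measured compounds sitting at limits, no step beyond the scatter is expected in this assay for compound 4. Compound 4 is therefore estimated at 250000 nM, with a range from 120000 nM to 500000 nM, and the step that the limit leaves unreadable from compound 1 to compound 4 is expected to be none beyond the scatter, most likely reported again only as a limit.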

Compound 4, half-maximal cytotoxic concentration: 145000 nM
Estimate against measurement, compound 4: 1.7-fold (0.24 log units) above; the measured number falls inside the stated range.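

In this assay compound 4 gives the first value among these compounds that is a number and not a limit, so this change on an aromatic carbon, para to a large group, yields a reading inside the range of the assay. The result is an at least 1.4-fold lower number from compound 1 to compound 4 (0.17 log units; that floor lies within the scatter) and so does not in itself establish a real difference between (4-sulfamoylpiperazin-1-yl)methyl and 3-(sulfamoylamino)piperidin-1-yl. Going by these compounds, the true size of the step stays unknown because compound 1 stands at a limit: the limit of > 217000 nM in this assay, at which 1 of the 4 values shown sits.

The change swaps the ring and its link to the aromatic carbon together, so any real difference cannot be assigned to either one. On these data alone, it is also open how an amine or a carboxylic acid in place of the sulfamoyl group would read in this assay against compound 4.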